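Bromo in Place of Methyl on Two Related Cores

This account rests on a few compounds, and the source may have more. Where it says the series, first, only, none or still open, it means among the compounds named here.

Measured in an ADME assay on HeLa cells (Homo sapiens) for cytotoxicity, read by resazurin assay, with a stated time of 2 days; on this read-out lower numbers stand for stronger inhibition and higher numbers for weaker inhibition:
Compound 1 `Cc1ccc(C(Br)C(Br)c2ncc([N+](=O)[O-])n2C)cc1` gives 11200 nM.
Compound 2 `Cc1ccc(/C=C/c2ncc([N+](=O)[O-])n2C)cc1` reaches only a limit of the assay, > 100000 nM.
Compound 3 `Cn1c([N+](=O)[O-])cnc1/C=C/c1ccc(Br)cc1` gives 72400 nM.

Of the two numbers recorded, compound 1 gives the lower one, and its gap to compound 3 lies beyond the usual scatter. Compound 2 sits at the limit of > 100000 nM in this assay, at which 1 of the 3 values shown sits, so its value is a limit rather than a number. The change from compound 2 to compound 3 is bromo in place of methyl on an aromatic carbon, and it made an at least 1.3-fold lower number from compound 2 to compound 3 (0.14 log units; that floor lies within the scatter). The difference between the core of compound 1 and the core of compound 2 is not broken down here.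

Compound 4 `Cn1c([N+](=O)[O-])cnc1C(Br)C(Br)c1ccc(Br)cc1` is not yet measured in this assay. It differs from compound 1 by bromo in place of methyl on an aromatic carbon, the same kind of change as that from compound 2 to compound 3. For compound 4 a step of a 1.3-fold lower number from compound 1 to compound 4 (0.12 log units; within the scatter) is expected, resting on the earlier step of an at least 1.3-fold lower number from compound 2 to compound 3 (0.14 log units; that floor lies within the scatter), whose floor lies within the scatter. Compound 4 is therefore estimated at 8500 nM, between 4000 nM and 18000 nM.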

Compound 4, half-maximal inhibitory concentration: 7940 nM
The estimate for compound 4 lay 1.1-fold (0.03 log units) above the measured number; the measured number falls inside the stated range.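

On the core of compound 1, bromo in place of methyl on an aromatic carbon gave a 1.4-fold lower number from compound 1 to compound 4 (0.15 log units; within the scatter) in this assay, so here the change produced no step beyond the scatter. Set beside the earlier case, the two cores cannot be told apart on this change, though one end of the comparison is not a number: the same change on two cores in this assay, an at least 1.3-fold lower number (0.14 log units; that floor lies within the scatter) from compound 2 to compound 3 and a 1.4-fold lower number (0.15 log units; within the scatter) from compound 1 to compound 4; the limit leaves it open whether they differ Compound 2 stands at a limit, > 100000 nM, so the full size of the earlier step stays unknown, and the two cores show only that nothing here contradicts carrying the change over, not that it would hold as a rule across the series.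

The compounds shown leave open how other groups on that aromatic carbon, such as a chloro group, a methoxy group or an amine, would read in this assay. Also open, as far as these compounds go, is whether the step would stay as small on a core that lacks the nitro group.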